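From Vinyl to Pyrrolidine on a Side Chain

The source may hold more compounds than are shown below. What is called first, only, known or untested is meant among the compounds shown, and "the series" means these compounds.

Of the compounds shown here, three sharing one core have numbers so far. In a functional assay on OVCAR-8 cells (Homo sapiens) for antiproliferative activity (a higher number here means a weaker inhibitor, a lower number a stronger inhibitor), compound 1 `Cn1ncc(Cl)c1-c1cc(C(=O)N[C@@H]2CN[C@H](CC(O)CO)C[C@H]2c2ccc(Cl)c(Cl)c2)oc1Cl` gives 1610 nM, compound 2 `Cn1ncc(Cl)c1-c1cc(C(=O)N[C@@H]2CN[C@H](CCCO)C[C@H]2c2ccc(Cl)c(Cl)c2)oc1Cl` gives 600 nM, and compound 3 `C=CC[C@@H]1C[C@@H](c2ccc(Cl)c(Cl)c2)[C@H](NC(=O)c2cc(-c3c(Cl)cnn3C)c(Cl)o2)CN1` gives 990 nM. Compound 3 holds the middle place among these three numbers, but it cannot be told apart from either of the others: a 1.6-fold lower number from compound 1 to compound 3 (0.21 log units; within the scatter), and a 1.7-fold higher number from compound 2 to compound 3 (0.22 log units; within the scatter). Among the measured compounds shown here, the only step beyond the scatter is a 2.7-fold lower number from compound 1 to compound 2 (0.43 log units; beyond the scatter), where hydrogen takes the place of a hydroxy on the chain.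

Compound 4 `Cn1ncc(Cl)c1-c1cc(C(=O)N[C@@H]2CN[C@H](CCN3CCCC3)C[C@H]2c2ccc(Cl)c(Cl)c2)oc1Cl` keeps the core and changes the same chain: (pyrrolidin-1-yl)methyl in place of vinyl on a saturated chain carbon bound to a saturated ring carbon. In words, (pyrrolidin-1-yl)methyl stands in place of vinyl on a saturated chain carbon bound to a saturated ring carbon. For the measured compounds named here, no measured compound carries a pyrrolidine on this chain, so the three steps above offer only indirect guidance. Even so, the largest of them, between compound 1 and compound 2, is modest, so no clear shift in either direction is expected in this assay. The expected step is a 1.2-fold lower number from compound 3 to compound 4 (0.09 log units; within the scatter), which is no real change. For compound 4 the estimated value is 800 nM, with an expected range from 280 nM to 2300 nM.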

Compound 4, half-maximal inhibitory concentration: 1840 nM
Beside the measured number, compound 4's estimate is 2.3-fold (0.36 log units) below it; the range from low to high includes it.
By their numbers in this assay, from the lowest: compounds 2, 3, 1 and 4 (each within the scatter of the next, the first and the last beyond it).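

In this assay, this position also accepts a chain ending in a pyrrolidine ring, and the result cannot be told apart from the vinyl or 1,2-dihydroxyethyl versions: a 1.9-fold higher number from compound 3 to compound 4 (0.27 log units; within the scatter), and a 1.1-fold higher number from compound 1 to compound 4 (0.06 log units; within the scatter). Among the compounds shown here, the one new step that clears the scatter is a 3.1-fold higher number from compound 2 to compound 4 (0.49 log units; beyond the scatter), and it is modest, so the hydroxymethyl end of compound 2 gains a second clear, though small, separation, after the one from compound 1. Compound 3 stays within the scatter of all three others, so these four chains, despite their different ends, give no large change in this assay.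

Still open, as far as these compounds go, is whether a carboxylic acid, a primary amine or a longer chain at this place would give a larger step, or whether the numbers would stay in the same range. Nothing in the data shown explains why compound 2 separates from compound 1 and compound 4.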